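Swapping a hydroxyphenyl for a pyridyl on the side chain

The source may hold more compounds than are shown below. What is called first, only, known or untested is meant among the compounds shown, and "the series" means these compounds.

Measured compounds:
compound 1, `Oc1ccccc1/C=C/C[C@H]1C[C@@H]([C@@H](O)c2ccccc2)CO[C@@H]1c1ccccc1`, 21800 nM
compound 2, `COc1ccc([C@H](O)[C@H]2CO[C@H](c3ccc(OC)c(OC)c3)[C@@H](C/C=C/c3ccc(OC)c(OC)c3)C2)cc1`, 46000 nM
compound 3, `COc1ccc(/C=C/C[C@@H]2C[C@@H]([C@@H](OC)c3ccc(OC)c(OC)c3)CO[C@H]2c2ccc(OC)c(OC)c2)cc1OC`, a limit, > 100000 nM

Of the compounds shown here, three on this shared core have been tested in a functional assay on HeLa cells (Homo sapiens) for cytotoxicity, read by WST assay, with a stated time of 48 h; a lower number here means a stronger inhibitor, a higher number a weaker inhibitor. Compound 1 gives the lowest of the two numbers, at 21800 nM. Its nearest neighbour is compound 2, which gives 46000 nM, a gap beyond the scatter of the assay. For compound 3 the assay reports only a limit, > 100000 nM. Among the measured compounds shown here, compound 1 and compound 2 differ in more than one place, so no single step between them is counted.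

The unmeasured compound 4, `O[C@@H](c1ccccc1)[C@H]1CO[C@H](c2ccccc2)[C@@H](C/C=C/c2cccnc2)C1`, differs from compound 1 in one place: pyridin-3-yl in place of 2-hydroxyphenyl on a double-bonded chain carbon bound to a double-bonded chain carbon. For the measured compounds named here, no measured pair isolates this change, so the direction is open. The two compounds with methoxy groups in place of the free phenol sit weaker, but they differ from compound 1 in several places at once. Compound 4 is therefore expected near compound 1, with the step of a 1.4-fold higher number from compound 1 to compound 4 (0.14 log units; within the scatter) estimated as small and toward a weaker value. Compound 4 is estimated at 30000 nM, between 10000 nM and 100000 nM.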

Compound 4, half-maximal inhibitory concentration: > 100000 nM
Compound 4 gave a limit, no number (the forecaster's own chance of this, stated with the estimate: 15%); middle value at least 3.3-fold (0.52 log units) from the limit.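

In this assay, among the compounds shown here, this pair gives the first comparison on the shared core that differs in one place, and it shows that this position on the side chain is sensitive to the change: pyridin-3-yl in place of 2-hydroxyphenyl gives an at least 4.5-fold higher number from compound 1 to compound 4 (0.66 log units; beyond the scatter). The change removes the hydrogen-bond donor of the leaving group and also puts a nitrogen into the aromatic ring, and this one pair cannot separate the two. The step is only a lower bound, as compound 4 stands at a limit of the assay and not at a number: the limit of > 100000 nM in this assay, at which 2 of the 4 values shown sit.

The compounds shown leave open how far compound 4 lies past that limit, and which part of the change carries the step. They also leave open how an unsubstituted phenyl or an aminophenyl group would read at this place.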